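Swapping a chloroaryl amide for a chloropyridyl amide

A few compounds are considered here, and "the series" means these few. Any claim that something is new, unique, unknown or untested is made for them only; others in the source may bear on it.

The compounds measured so far, with their values in a functional assay on LoVo cells (Homo sapiens) for inhibition, read by MTT assay, with a stated time of 72 h; a lower number here means a stronger inhibitor, a higher number a weaker inhibitor:

Compound 1, `CCCNC(=O)c1ccc(Oc2nc(-c3c(C)noc3C)cnc2N)cc1`: 17500 nM
Compound 2, `Cc1noc(C)c1-c1cnc(N)c(Oc2ccc(C(=O)NC3CCCCC3)cc2)n1`: 21600 nM
Compound 3, `Cc1noc(C)c1-c1cnc(N)c(Oc2ccc(C(=O)Nc3ccc(Cl)cc3)cc2)n1`: 1920 nM

Compound 3 has the lowest number of the three. The two measured steps reaching it are both beyond the scatter: a 9.1-fold lower number from compound 1 to compound 3 (0.96 log units; beyond the scatter) and an 11-fold lower number from compound 2 to compound 3 (1.05 log units; beyond the scatter), whereas the step of a 1.2-fold higher number from compound 1 to compound 2 (0.09 log units; within the scatter) stays within the scatter. Each of these steps exchanges one substituent on the amide-type nitrogen for another of a different kind.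

Compound 4, `Cc1noc(C)c1-c1cnc(N)c(Oc2ccc(C(=O)Nc3ccc(Cl)cn3)cc2)n1`, has not been measured in this assay. The change from compound 3 is 5-chloropyridin-2-yl in place of 4-chlorophenyl on an amide-type nitrogen. Within the data shown here, none of the measured steps bears directly on this change: they compare propyl, cyclohexyl and 4-chlorophenyl on that nitrogen, and no measured pair compares a carbocyclic aromatic ring with a heteroaromatic one at this position. Among the measured compounds shown here, the only guide is therefore that the substituent remains a six-membered aromatic ring carrying chlorine, as in compound 3, which gives 1920 nM.

On that basis the step of a 1.3-fold higher number from compound 3 to compound 4 (0.11 log units; within the scatter) is expected to stay within the scatter. Compound 4 is estimated at 2500 nM, with a range from 800 nM to 8000 nM.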

Compound 4, half-maximal inhibitory concentration: 9180 nM
Compound 4: the middle estimate sits 3.7-fold (0.56 log units) below what was measured, outside the stated range (above it).
By their numbers in this assay, from the lowest: compound 3; then compounds 4, 1 and 2 (each within the scatter of the next, the first and the last beyond it).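

In this assay, the amide-type nitrogen proves sensitive to more than the presence of a six-membered aromatic ring carrying chlorine: placing 5-chloropyridin-2-yl there in place of 4-chlorophenyl gives a 4.8-fold higher number from compound 3 to compound 4 (0.68 log units; beyond the scatter), so a single hetero atom in that ring is enough to give a step beyond the scatter. The pyridine-containing amide also keeps only part of the advantage that 4-chlorophenyl showed over the non-aromatic substituents: against cyclohexyl the change gives a 2.4-fold lower number from compound 2 to compound 4 (0.37 log units; beyond the scatter), still beyond the scatter, whereas against propyl it gives a 1.9-fold lower number from compound 1 to compound 4 (0.28 log units; within the scatter), which lies within the scatter. Nothing available here accounts for the difference between the two chlorinated rings.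

The compounds shown leave open how much of the result belongs to the chlorine and how much to the ring itself, a question that an unsubstituted phenyl or an unsubstituted pyridin-2-yl on the same nitrogen would address. They also leave open whether the placing of the ring nitrogen matters, as a 6-chloropyridin-3-yl group at this nitrogen would show.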